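Replacing the Side-Chain Ring of Compound 2 with a Sulfamoylamino Group

This account rests on a few compounds, and the source may have more. Where it says the series, first, only, none or still open, it means among the compounds named here.

Compound 1 `O=C1O[C@@H](CN2CCCCC2)CN1c1ccc(-n2cc(-c3ccccn3)cn2)c(F)c1`: in an ADME assay on L02 cells (Homo sapiens) for cytotoxicity, read by MTT assay, with a stated time of 48 h (a higher number here means a weaker inhibitor, a lower number a stronger inhibitor), compound 1 gives > 400 ug/mL, which is a limit of the assay and not a number.
Compound 2 `O=C1CCC(=O)N1C[C@H]1CN(c2ccc(-n3cc(-c4ccccn4)cn3)c(F)c2)C(=O)O1`: in this assay compound 2 gives > 400 ug/mL, again a limit rather than a number.
Compound 3 `O=CNC[C@H]1CN(c2ccc(-n3cc(-c4ccccn4)cn3)c(F)c2)C(=O)O1`: in this assay compound 3 gives > 400 ug/mL, likewise a limit.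

Compound 2 therefore stands nowhere in particular on a scale: it is known only by a limit, and the two other values are limits as well, so that all three compounds sit at the limit of > 400 ug/mL in this assay, at which 3 of the 3 values shown sit. None of the three steps between them can be read: a step that the two limits leave unreadable from compound 1 to compound 2, a step that the two limits leave unreadable from compound 1 to compound 3 and a step that the two limits leave unreadable from compound 2 to compound 3 all remain of unknown size, because both ends are limits.

Compound 4 `CN(C)S(=O)(=O)NC[C@H]1CN(c2ccc(-n3cc(-c4ccccn4)cn3)c(F)c2)C(=O)O1` is the next compound. It differs from compound 2 in one place: (dimethylsulfamoyl)amino in place of 2,5-dioxopyrrolidin-1-yl on a saturated chain carbon bound to a saturated ring carbon. Among the measured compounds shown here, the step most like it among the measured ones is the one from compound 2 to compound 3, where the 2,5-dioxopyrrolidin-1-yl group also gave way to a chain group without a ring, and that step was unreadable. No direction can thus be expected for the step in this assay, and the most reasonable expectation is that compound 4 will again end at the limit, so that the expected step that the limit leaves unreadable from compound 2 to compound 4 is effectively none. Compound 4 is accordingly estimated at 600 ug/mL, with a range from 250 ug/mL to 1500 ug/mL.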

Compound 4, half-maximal inhibitory concentration: 158 ug/mL
Compound 4: middle estimate off by 3.8-fold (0.58 log units), on the high side; measured number below the stated range.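

Among the compounds shown here, compound 4 is the first compound here that gives a true number in this assay and so shows that the group on this saturated chain carbon can move the read-out away from the limit, towards stronger inhibition of the cells. The (dimethylsulfamoyl)amino group gives an at least 2.5-fold lower number from compound 2 to compound 4 (0.40 log units; beyond the scatter) in place of 2,5-dioxopyrrolidin-1-yl, an at least 2.5-fold lower number from compound 1 to compound 4 (0.40 log units; beyond the scatter) in place of piperidin-1-yl, and an at least 2.5-fold lower number from compound 3 to compound 4 (0.40 log units; beyond the scatter) when dimethylsulfamoyl stands in place of formyl on the amine nitrogen. Each of these steps gives only the smallest possible size, and the true sizes may be larger, because the compound at the start of each step is known only by a limit: the limit of > 400 ug/mL in this assay, at which 3 of the 4 values shown sit.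

Going by these compounds, whether the change depends on the sulfamoyl part or on its methyl groups stays open, and a methanesulfonylamino group or an unsubstituted sulfamoylamino group on the same chain carbon would help to separate the two. On these data alone, it is also open whether only sulfur-containing groups lower the number here, or whether a primary amine or a carboxylic acid in this place would do the same.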